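Acyclic amine variation on the shared core of compound 1

This account rests on a few compounds, and the source may have more. Where it says the series, first, only, none or still open, it means among the compounds named here.

In an assay on isolated protein for displacement of a labelled ligand from melanin-concentrating hormone receptor 1 (Homo sapiens) (a higher number here means a weaker inhibitor, a lower number a stronger inhibitor), compound 1 `CC(C)N(C)c1ccc2cc(NC(=O)CCc3ccc(C(F)(F)F)cc3)ccc2n1` gives 2 nM. Compound 2 `CN(c1ccc2cc(NC(=O)CCc3ccc(C(F)(F)F)cc3)ccc2n1)C1CCCC1` gives 2 nM and compound 3 `O=C(CCc1ccc(C(F)(F)F)cc1)Nc1ccc2nc(N3CCCCCC3)ccc2c1` gives 36 nM; compound 1 therefore stands level with compound 2, the two together the lowest of the three numbers, with compound 3 the furthest away. Compound 4 `CCN(CC)c1ccc2cc(NC(=O)CCc3ccc(C(F)(F)F)cc3)ccc2n1` carries the change (diethylamino in place of isopropyl(methyl)amino on an aromatic carbon). Going by the values given here, two measured steps bear on it: no change at the digits printed from compound 1 to compound 2 (within the scatter) shows that a different alkyl on that nitrogen leaves this assay unchanged, whereas an 18-fold higher number from compound 1 to compound 3 (1.26 log units; beyond the scatter) shows that closing the amine into azepan-1-yl costs a great deal. Diethylamino, like the amine of compound 2, is acyclic, so the expected step is a 1.5-fold higher number from compound 1 to compound 4 (0.18 log units; within the scatter). Compound 4 is accordingly estimated at 3 nM, between 1 nM and 10 nM.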

Compound 4, half-maximal inhibitory concentration: 88 nM
Compound 4: middle estimate off by 29-fold (1.47 log units), on the low side; the whole stated range lies below it.
By their numbers in this assay, from the lowest: compounds 1 and 2 (each within the scatter of the next); then compound 3; then compound 4.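

Diethylamino and isopropyl(methyl)amino have the same atoms, joined differently, yet this rearrangement at the position next to the ring nitrogen gives a 44-fold higher number from compound 1 to compound 4 (1.64 log units; beyond the scatter) in this assay. Being acyclic therefore does not secure a low number: the change gives a 44-fold higher number from compound 2 to compound 4 (1.64 log units; beyond the scatter), and even azepan-1-yl fares better, with a 2.4-fold higher number from compound 3 to compound 4 (0.39 log units; beyond the scatter). No measurement shown here accounts for this difference.

Open, on these data alone, is whether ethyl(methyl)amino or diisopropylamino would sit with compound 1 or with compound 4, and so whether the low number depends on the methyl, on the branched group or on both.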